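This account rests on a few compounds, and the source may have more. Where it says the series, first, only, none or still open, it means among the compounds named here.

Three compounds of the series have been measured in an assay on isolated protein for agonist activity at melatonin receptor type 1C (Xenopus laevis), read by spectrophotometry; a higher number here means that more compound is needed for the effect, a lower number that less compound is needed:

compound 1, `COc1ccc(CNC(C)=O)cc1F`: 1510 nM
compound 2, `CCC(=O)NCc1ccc(OC)c(F)c1`: 1050 nM
compound 3, `COc1cc(CNC(C)=O)ccc1F`: 2090 nM

Compound 1 and compound 2 share a core and differ in one place, by methyl in place of hydrogen on a saturated chain carbon bound to a carbonyl carbon. The step that this change made, a 1.4-fold lower number from compound 1 to compound 2 (0.16 log units; within the scatter), is small and does not stand out from the repeat scatter of this assay. Compound 3 is built from the same atoms as compound 1, joined differently; the difference between the two cores is not broken down here. The values of compound 3, compound 1 and compound 2 all lie within the usual scatter of one another, so no order among the three can be read from them.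

Compound 4, `CCC(=O)NCc1ccc(F)c(OC)c1`, has not yet been measured. It differs from compound 3 by methyl in place of hydrogen on a saturated chain carbon bound to a carbonyl carbon. The place is described in the same words as for the change from compound 1 to compound 2, so this is the same change made on the core of compound 3. Among the measured compounds shown here, with only one prior example of the change, the expectation rests on that single step: a step of about the same small size is expected from compound 3 to compound 4, a 1.4-fold lower number from compound 3 to compound 4 (0.14 log units; within the scatter), because the earlier step of a 1.4-fold lower number from compound 1 to compound 2 (0.16 log units; within the scatter) was itself within the scatter. On that basis compound 4 is estimated at 1500 nM in this assay. The expected range for compound 4 runs from 750 nM to 3200 nM, wide enough to take in the scatter of a single measurement as well as the uncertainty of transferring one observed step to a differently joined core.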

Compound 4, half-maximal effective concentration: 2880 nM
The estimate for compound 4 lay 1.9-fold (0.28 log units) below the measured number; the measured number falls inside the stated range.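

In this assay, methyl in place of hydrogen on a saturated chain carbon bound to a carbonyl carbon gives a 1.4-fold higher number from compound 3 to compound 4 (0.14 log units; within the scatter) on the core of compound 3. Set beside the earlier step, the change reads alike on the two cores, with no difference that the data can separate: the same change on two cores in this assay, a 1.4-fold lower number (0.16 log units; within the scatter) from compound 1 to compound 2 and a 1.4-fold higher number (0.14 log units; within the scatter) from compound 3 to compound 4, 2.0-fold (0.30 log units) apart, within the scatter of two such steps. This shows that, on these two cores, going from acetamido to propanoylamino leaves the number within the scatter, but it does not show that the change acts in opposite directions or that the two steps are truly equal, and two small steps give no rule for a further core and no explanation of the result.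

Going by these compounds, whether a longer chain such as butanoylamino, a branched chain such as isobutyrylamino or a ring-bearing group such as cyclopropanecarbonylamino would give a step beyond the scatter remains open. On these data alone, all the values shown come from this assay, so how this change would read on a third core, or in a different assay, also remains open.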